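The source may report more compounds than this note shows. Statements on the series, on what has been measured and on what is new or still open speak of the compounds shown alone.

Measured compounds:
compound 1, `Cn1c(CO[C@@H]2COc3nc([N+](=O)[O-])cn3C2)cnc1-c1ccc(C#N)cc1` — in an ADME assay on Vero cells (Chlorocebus sabaeus) for cytotoxicity, with a stated time of 72 h (a higher number here means a weaker inhibitor, a lower number a stronger inhibitor), compound 1 gives > 128000 nM, a limit of the assay rather than a number.
compound 2, `Cn1c(CO[C@@H]2COc3nc([N+](=O)[O-])cn3C2)cnc1-c1ccc(F)cc1` — in this assay compound 2 gives > 128000 nM, again a limit and not a number.

Compound 2 thus stands only at the edge of what this assay can report, with nothing measurable toward stronger inhibition. Among the compounds with values here, both values sit at the same point, (the limit of > 128000 nM in this assay, at which 2 of the 2 values shown sit), so the single measured step, a step that the two limits leave unreadable from compound 1 to compound 2, cannot be read as a size or a direction.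

Compound 3, `COc1ccc(-c2ncc(CO[C@@H]3COc4nc([N+](=O)[O-])cn4C3)n2C)cc1F`, is reached from compound 2 by one change: 3-fluoro-4-methoxyphenyl in place of 4-fluorophenyl on an aromatic carbon. Within the data shown here, the only measured step that bears on it is the one from compound 1 to compound 2, and that step is unreadable, so it gives no pointer toward a rise or a fall. With no readable step to draw on, the expected change in this assay from compound 2 to compound 3 is a step that the limit leaves unreadable from compound 2 to compound 3, that is, nothing beyond the scatter. For compound 3 the estimate in this assay is 150000 nM, with an expected range from 60000 nM to 400000 nM, most likely again returned as a limit.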

Compound 3, half-maximal inhibitory concentration: > 128000 nM
Compound 3: only a limit was reported (the forecaster's own chance of this, stated with the estimate: 85%); the middle value is on the limit's open side.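

In this assay compound 3 gives > 128000 nM, a limit and not a number. The steps linking compound 1, compound 2 and compound 3 therefore cannot be read for size or direction, and all three sit at one point: the limit of > 128000 nM in this assay, at which 3 of the 3 values shown sit.

Going by these compounds, whether 4-cyanophenyl, 4-fluorophenyl and 3-fluoro-4-methoxyphenyl differ at all in this assay stays open.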